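A few compounds are considered here, and "the series" means these few. Any claim that something is new, unique, unknown or untested is made for them only; others in the source may bear on it.

For the measured compounds named here, in a functional assay on A549 cells (Homo sapiens), read by MTT assay, with a stated time of 72 h (on this read-out higher numbers stand for weaker inhibition and lower numbers for stronger inhibition), compound 1 `CNc1ncnc2c1c(-c1ccco1)cn2[C@@H]1O[C@H](CO)[C@@H](O)[C@H]1O` gives 2570 nM as the only true number available, so its standing can be judged against little else. Compound 2 `Nc1nc(N)c2c(-c3ccsc3)cn([C@@H]3O[C@H](CO)[C@@H](O)[C@H]3O)c2n1` reads > 100000 nM in this assay and that entry is a limit of the assay, not a number. Going by the values given here, no step links two measured compounds, so nothing measured calibrates the change that follows. Compound 3 `CNc1ncnc2c1c(I)cn2[C@@H]1O[C@H](CO)[C@@H](O)[C@H]1O` keeps the core of compound 1 and carries iodo in place of furan-2-yl on an aromatic carbon, a swap counted as iodo in place of furan-2-yl on an aromatic carbon in full. In this assay a modest shift towards weaker inhibition is expected, though it may stay close to the scatter, and the uncertainty is wide. The estimated move is a 1.9-fold higher number from compound 1 to compound 3 (0.29 log units; within the scatter) and remains only an expectation. For compound 3 the expected value is 5000 nM within an estimated range of 800 nM to 35000 nM for now.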

Compound 3, half-maximal inhibitory concentration: > 100000 nM
Compound 3: a limit, no number; the forecaster's own chance of this, stated with the estimate: 15%; at least 20-fold (1.30 log units) between middle value and limit.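

In this assay, setting iodo in place of furan-2-yl on this aromatic carbon gives an at least 38-fold higher number from compound 1 to compound 3 (1.59 log units; beyond the scatter), the first step measured at this position, and it shows that the position is not indifferent to what it carries. On the shared core, a single iodine atom does not keep the inhibition that compound 1 shows with its five-membered aromatic ring. Compound 3 reads > 100000 nM, which is a limit and not a number, so the step gives only a lower bound, and that limit is shared with another compound: the limit of > 100000 nM in this assay, at which 2 of the 3 values shown sit.

The compounds shown do not tell whether furan-2-yl itself is needed or whether another ring, such as phenyl, would serve at this carbon. Where a methyl group or an amine would fall at this position also stays open.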